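Halogen swap on the aryl group of a shared core

The source may report more compounds than this note shows. Statements on the series, on what has been measured and on what is new or still open speak of the compounds shown alone.

Compound 1 `CCCNC(=O)c1cc(Oc2ccc(NC(=O)c3cc4cccnc4n(-c4ccc(F)cc4)c3=O)cc2)ccn1`: 960 nM
Compound 2 `CCCNC(=O)c1cc(Oc2ccc(NC(=O)c3cc4cccnc4n(-c4ccc(Br)cc4F)c3=O)cc2)ccn1`: "not determined" (no result reported)

Compound 1 was tested in a functional assay on U-87MG ATCC cells for antiproliferative activity against U-87 MG (Homo sapiens), read by MTT assay, with a stated time of 72 h (a higher number here means a weaker inhibitor, a lower number a stronger inhibitor), and gives 960 nM. Compound 2 carries a 4-bromo-2-fluorophenyl on the aromatic nitrogen of the shared core, but in this assay compound 2 is recorded as "not determined" (no result reported), so it stands at no number of its own. Compound 3 `CCCNC(=O)c1cc(Oc2ccc(NC(=O)c3cc4cccnc4n(-c4ccc(F)c(Cl)c4)c3=O)cc2)ccn1` is the next member: 3-chloro-4-fluorophenyl in place of 4-bromo-2-fluorophenyl on an aromatic nitrogen. Since compound 2 has no value, the size of the step to compound 3 cannot be computed from the measurements. The closest anchor is compound 1, whose aryl group differs from that of compound 3 only by the chlorine. In this assay compound 1 gives 960 nM, and compound 3 is expected to match that value, with any difference staying within scatter. Compound 3 is therefore estimated at 750 nM, with a range from 200 nM to 2800 nM.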

Compound 3, half-maximal inhibitory concentration: 3590 nM
Compound 3: the middle estimate sits 4.8-fold (0.68 log units) below what was measured; measured number above the stated range.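

In this assay, putting chloro in place of hydrogen on an aromatic carbon of the aryl group gives a 3.7-fold higher number from compound 1 to compound 3 (0.57 log units; beyond the scatter), a step beyond the scatter. Going by these compounds alone, this is the first readable step at this position on the aromatic nitrogen of the shared core, and it shows that the assay responds to a single added halogen on this aryl group, in the direction of weaker inhibition. Nothing measured here accounts for this loss.

The steps involving compound 2 cannot be read, so the 4-bromo-2-fluorophenyl group cannot be placed against the aryl groups of the other two compounds. The compounds shown also leave open how a methoxy group, an amine or a nitrile would compare with chloro on this aryl group.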